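This account rests on a few compounds, and the source may have more. Where it says the series, first, only, none or still open, it means among the compounds named here.

Of the compounds shown here, three sharing one core have been measured in a functional assay on MIA PaCa-2 cells (Homo sapiens) for inhibition, read by MTT assay, with a stated time of 7 days; a lower number here means a stronger inhibitor, a higher number a weaker inhibitor. Compound 1 `CCOC(=O)[C@@H]1CCCN(S(=O)(=O)c2ccc(S(=O)(=O)N(C)C)cc2)C1` gives 900 nM. Compound 2 `CCOC(=O)[C@@H]1CCCN(S(=O)(=O)c2ccc(S(=O)(=O)N(CC)C(C)C)cc2)C1` gives 1000 nM. Compound 3 `CCOC(=O)[C@@H]1CCCN(S(=O)(=O)c2ccc(C(=O)N(CC)CC)cc2)C1` gives 800 nM. Compound 3 carries the lowest of the three numbers, but its neighbours sit close: the step of a 1.1-fold lower number from compound 1 to compound 3 (0.05 log units; within the scatter) and the step of a 1.3-fold lower number from compound 2 to compound 3 (0.10 log units; within the scatter) both fall inside the usual scatter, so no ranking among the three can be read from them.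

Compound 4 `CCCN(CC)S(=O)(=O)c1ccc(S(=O)(=O)N2CCC[C@@H](C(=O)OCC)C2)cc1` has not yet been measured. Its difference from compound 3 is ethyl(propyl)sulfamoyl in place of diethylcarbamoyl on an aromatic carbon. Within the data shown here, three measured steps bear on this change. The two steps just named exchange a sulfamoyl group for a carbamoyl group on an aromatic carbon and barely move the number; the change from compound 3 to compound 4 runs the opposite way, putting a sulfamoyl group back. The third, a 1.1-fold higher number from compound 1 to compound 2 (0.05 log units; within the scatter), alters the two groups on the sulfamoyl nitrogen and is equally flat. From this, no step beyond the scatter is expected in this assay in either direction. The estimate for compound 4 is 900 nM, with a range from 450 nM to 1800 nM, which means an expected step of a 1.1-fold higher number from compound 3 to compound 4 (0.05 log units; within the scatter).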

Compound 4, half-maximal inhibitory concentration: 300 nM
The estimate for compound 4 lay 3.0-fold (0.48 log units) above the measured number; the whole stated range lies above it.
By their numbers in this assay, from the lowest: compound 4; then compounds 3, 1 and 2 (each within the scatter of the next).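

In this assay, the groups on the sulfamoyl nitrogen can move the number after all, a point the flat earlier steps gave no sign of. Ethyl(propyl)sulfamoyl on this aromatic carbon, para to a large group, gives a 2.7-fold lower number from compound 3 to compound 4 (0.43 log units; beyond the scatter) in place of diethylcarbamoyl, and ethyl(propyl)amino gives a 3.0-fold lower number from compound 1 to compound 4 (0.48 log units; beyond the scatter) in place of dimethylamino, so compound 4 separates from all three earlier compounds, though only modestly. The sharpest contrast is propyl in place of isopropyl on the sulfonamide nitrogen, with a 3.3-fold lower number from compound 2 to compound 4 (0.52 log units; beyond the scatter), which shows that a straight chain and a branched one are not interchangeable at this nitrogen, although no measurement shown explains the difference.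

As far as these compounds go, what remains open is how far this trend runs along the chain, since a butyl or longer chain on the sulfamoyl nitrogen, or two propyl groups there, could extend the gain or reverse it. From the compounds shown here alone, the ethyl ester also stays the same in all four compounds, so the effect of a carboxylic acid or an amide at that place on the shared core is unknown.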